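Swapping alkyl groups on the imidazole of compound 3

This account rests on a few compounds, and the source may have more. Where it says the series, first, only, none or still open, it means among the compounds named here.

Of the compounds shown here, three sharing one core have been measured in an assay on isolated protein for binding affinity to Melanocortin receptor 4 (Homo sapiens); on this read-out lower numbers stand for stronger inhibition and higher numbers for weaker inhibition. Compound 1 `COc1ccc(Br)cc1CCc1c(Cl)cccc1-c1nccn1C` gives 300 nM. Compound 2 `COc1ccc(Br)cc1CCc1c(Cl)cccc1-c1ncc2n1CCCC2` gives 340 nM. Compound 3 `COc1ccc(Br)cc1CCc1ccccc1-c1ncc(C)n1C` gives 180 nM, the lowest of the three numbers, though its gaps to compound 1 and compound 2 both fall inside the usual scatter, so no ranking among them can be claimed.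

Compound 4 `CCc1cn(C)c(-c2ccccc2CCc2cc(Br)ccc2OC)n1` is not yet measured. It differs from compound 3 by 4-ethyl-1-methyl-1H-imidazol-2-yl in place of 1,5-dimethyl-1H-imidazol-2-yl on an aromatic carbon. Among the measured compounds shown here, no measured step changes the imidazole in just this way. The closest comparison is the step on the same imidazole a 1.1-fold higher number from compound 1 to compound 2 (0.05 log units; within the scatter), which was a larger alteration and still stayed within the scatter. For the measured compounds named here, compounds 1 and 3 differ in two places and give no clean step, but their numbers also sit close together.

On that basis compound 4 is expected to show a step of a 1.1-fold higher number from compound 3 to compound 4 (0.05 log units; within the scatter), that is, nothing beyond the scatter. The estimate for compound 4 in this assay is 200 nM, with a range from 80 nM to 500 nM.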

Compound 4, inhibition constant: 690 nM
For compound 4 the middle estimate is 3.5-fold (0.54 log units) below the measured one, and the stated range ends below it.
By their numbers in this assay, from the lowest: compounds 3, 1 and 2 (each within the scatter of the next); then compound 4.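

Among the compounds shown here, this is the first change on the imidazole to go beyond the scatter: in this assay, 4-ethyl-1-methyl-1H-imidazol-2-yl in place of 1,5-dimethyl-1H-imidazol-2-yl gives a 3.8-fold higher number from compound 3 to compound 4 (0.58 log units; beyond the scatter). Size alone does not track the result across the two steps, since a 1.1-fold higher number from compound 1 to compound 2 (0.05 log units; within the scatter) stayed within the scatter with 9 heavy atoms in place of 6, whereas this change has 8 in place of 7 and still shifts the number, so small alkyl changes on this imidazole cannot be assumed to be neutral. No measurement shown here accounts for this step.

The two groups differ both in the alkyl chain and in where it stands in the group name, and the compounds shown do not separate these two changes. From the compounds shown here alone, how a propyl chain, or an amine on that chain, would read in this assay also remains open.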